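The source may report more compounds than this note shows. Statements on the series, on what has been measured and on what is new or still open speak of the compounds shown alone.

Working notes on the series. Three compounds have so far been run in an ADME assay on microsomes from liver (Mus musculus) for metabolic stability, read by LC-MS, with a stated time of 30 min, tested at 1 uM; on this read-out lower numbers stand for a less stable compound and higher numbers for a more stable compound. Compound 1 `O=C(NCc1ccc(S(=O)(=O)c2ccccc2C(F)(F)F)cc1)c1cc2cnccc2[nH]1` gives 41% in this assay. Compound 2 `O=C(NCc1ccc(S(=O)(=O)N2CCCCC2)cc1)c1cc2cnccc2o1` gives 4.6% in this assay. Compound 3 `O=C(NCc1ccc(S(=O)(=O)c2cccc(C(F)(F)F)c2)cc1)c1ccc2nccn2c1` gives 17% in this assay. Compound 1 stands highest of the three numbers; the nearest is compound 3, whose number lies lower by an amount beyond the scatter, and the furthest is compound 2, lower still by an amount beyond the scatter. Within the data shown here, the three measured compounds differ from one another in more than one place, so no pair among them isolates a single change, and none of them bears directly on the change now considered.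

The next compound, compound 4 `O=C(NCc1ccc(S(=O)(=O)c2ccccc2)cc1)c1cc2cnccc2[nH]1`, differs from compound 1 in one place: hydrogen in place of trifluoromethyl on an aromatic carbon. Among the measured compounds shown here, no measured pair tracks this change, so there is no step to lean on. The expectation is a modest move downward in this assay, a number 9 percentage points lower from compound 1 to compound 4 (within the scatter), with a step that stays within the scatter held to be nearly as likely as one beyond it. On that basis compound 4 is expected to give about 32% in this assay, with a range from 15% to 55%.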

Compound 4, percent of the compound remaining: 54%
Beside the measured number, compound 4's estimate is 22 percentage points below it; the range from low to high includes it.
By their numbers in this assay, from the lowest: compound 2; then compound 3; then compound 1; then compound 4.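

In this assay, among these compounds, hydrogen in place of trifluoromethyl on an aromatic carbon, ortho to a large group, gives a number 13 percentage points higher from compound 1 to compound 4 (beyond the scatter) and is the first step that isolates a single place. With the rest of the structure unchanged, the change from 2-(trifluoromethyl)phenyl to phenyl shows that trifluoromethyl at this position is not required to retain compound in this read-out, as the number rises once the group is gone. Nothing available accounts for the direction or size of this step, so the result stands as an observation about this one pair.

Among the compounds shown here, still open is whether the same step would appear with a different core, as the only measured pair shares the core of compound 1 and compound 4. From the compounds shown here alone, it is also open how other groups at this position would read, such as a methyl, a methoxy, a chlorine, a nitrile or an amine, and so whether the higher number belongs to hydrogen itself or simply to the absence of trifluoromethyl.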